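The source may hold more compounds than are shown below. What is called first, only, known or untested is meant among the compounds shown, and "the series" means these compounds.

Measured so far in an assay on HEK293 cells for inhibition of Voltage-dependent T-type calcium channel subunit alpha-1G (Homo sapiens), read by patch clamp; on this read-out higher numbers stand for weaker inhibition and lower numbers for stronger inhibition:
- compound 1 `CCCc1nc(-c2ccccc2)c(CNCCCN2CCN(c3ccccc3Cl)CC2)o1` gives 2800 nM
- compound 2 `CCCc1nc(-c2ccccc2)c(CNCCCN2CCN(c3ccc(C(F)(F)F)cc3)CC2)o1` gives 7250 nM

Among the measured compounds shown here, compound 2 holds the highest of the two numbers; its only neighbour is compound 1, and the step of a 2.6-fold higher number from compound 1 to compound 2 (0.41 log units; beyond the scatter) is modest but beyond the scatter. Compound 3 `CCCc1nc(-c2ccccc2)c(CNCCCN2CCN(c3ccc(C)cc3)CC2)o1` is not yet measured. It differs from compound 2 in one place: methyl in place of trifluoromethyl on an aromatic carbon, para to a large group. For the measured compounds named here, no measured step changes this position alone. Going by the values given here, the one step there is, a 2.6-fold higher number from compound 1 to compound 2 (0.41 log units; beyond the scatter), swaps the whole aryl group on the ring nitrogen, so it bears on the question only loosely: it shows that the aryl substituent in this part of the molecule moves the number by a modest amount, with compound 2 at the higher end of the pair. On that basis the step of a 1.5-fold lower number from compound 2 to compound 3 (0.16 log units; within the scatter) is expected to be small, possibly none beyond the scatter, with at most a slight lean toward a lower number. Compound 3 is estimated at 5000 nM, with a range from 1800 nM to 14000 nM.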

Compound 3, half-maximal inhibitory concentration: 130000 nM
The estimate for compound 3 lay 26-fold (1.41 log units) below the measured number; the measured number lies above the stated range.
By their numbers in this assay, from the lowest: compound 1; then compound 2; then compound 3.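

In this assay, exchanging trifluoromethyl for methyl on the aromatic carbon para to a large group gives an 18-fold higher number from compound 2 to compound 3 (1.25 log units; beyond the scatter) and so marks this single substituent as a far stronger control on the number than the whole-aryl swap, which gave only a 2.6-fold higher number from compound 1 to compound 2 (0.41 log units; beyond the scatter) as its step. The change from 2-chlorophenyl to 4-methylphenyl gives a 46-fold higher number from compound 1 to compound 3 (1.67 log units; beyond the scatter) and leaves compound 3 with the weakest inhibition of the three, so the aryl group on the ring nitrogen spans a much wider range than the first pair showed. No supporting measurement accounts for the sharp difference between these two groups.

Open, on these data alone, is whether a hydrogen, a methoxy group or a chlorine at the position of the methyl in compound 3 would stay near compound 2 or near compound 3, which would show whether methyl is an isolated poor choice or trifluoromethyl an unusually favourable one. Also open, as far as these compounds go, is whether the same exchange of groups has a similar effect on a longer or shorter chain between the shared core and the ring nitrogen.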